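The compounds below may be only part of what the source reports. "The series", "measured", "known", "first", "only" and "open" are said of these compounds alone.

The compounds here share one core, a propargylic ether of an enol ester, and differ only in what sits on the carbon between the alkyne and the ether oxygen. Compound 2, `CCCC(C#CC(=O)OC)O/C=C/C(=O)OC`, carries a propyl chain there, and in a functional assay on SW1573 cells (Homo sapiens) for antiproliferative activity, read by sulforhodamine B assay, with a stated time of 48 h (on this read-out higher numbers stand for weaker inhibition of growth and lower numbers for stronger inhibition of growth), compound 2 gives 320 nM. Among the compounds with values here, that is the lower of the two numbers measured so far. Compound 1, `COC(=O)C#CC(O/C=C/C(=O)OC)C(C)c1ccccc1`, bears a methyl and a phenyl ring at that carbon, and in this assay compound 1 gives 1200 nM, a weaker result than compound 2 by a gap beyond the usual scatter. Compound 3, `C#CCO/C=C/C(=O)OC`, has only hydrogen at that position, and in this assay compound 3 gives > 100000 nM, which is a limit of the assay rather than a number (the limit of > 100000 nM in this assay, at which 1 of the 3 values shown sits).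

Compound 4, `COC(=O)C#CC(CC(C)C)O/C=C/C(=O)OC`, has not yet been measured. It differs from compound 2 by a single change: methyl in place of hydrogen on a saturated chain carbon bound to two saturated chain carbons. Within the data shown here, no two measured compounds differ by a change of this kind. The direction is therefore uncertain. The step from compound 2 to compound 4 is expected to be small, a 1.3-fold higher number from compound 2 to compound 4 (0.10 log units; within the scatter), within the scatter. Compound 4 is therefore expected to give about 400 nM, somewhere between 150 nM and 1200 nM.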

Compound 4, concentration for 50% growth inhibition: 380 nM
Compound 4: the middle estimate sits 1.1-fold (0.02 log units) above what was measured; measured number inside the range.
By their numbers in this assay, from the lowest: compounds 2 and 4 (each within the scatter of the next); then compound 1. At a limit, above all of these: compound 3.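

Replacing propyl with isobutyl on the shared core gives a 1.2-fold higher number from compound 2 to compound 4 (0.07 log units; within the scatter) in this assay. This is the first pair shown that differs in one place only, and it shows that this chain can carry a methyl branch at the carbon bound to two saturated chain carbons while the two numbers stay within the usual scatter of each other. Nothing shown here gives a reason why these two numbers lie so close.

As far as these compounds go, how a longer chain such as hexyl would read in this assay remains open, as does a cyclohexyl ring at the same carbon. From the compounds shown here alone, it is also open whether a chain ending in an amine or a carboxylic acid would fit the same pattern as propyl and isobutyl.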